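Indole in Place of Tolyl on the Hydrazone Carbon

A few compounds are considered here, and "the series" means these few. Any claim that something is new, unique, unknown or untested is made for them only; others in the source may bear on it.

Compound 1 `CCCSc1nc(N/N=C/c2ccc(C)cc2)c2nnn(Cc3ccccc3)c2n1` bears a 4-methylphenyl group on the hydrazone carbon. In a functional assay on ECa-109 cells (Homo sapiens) for antiproliferative activity, read by MTT assay, with a stated time of 72 h (a higher number here means a weaker inhibitor, a lower number a stronger inhibitor), compound 1 reaches only the limit of the assay, > 64000 nM, so it stands at the limit of > 64000 nM in this assay, at which 1 of the 3 values shown sits, and no number is known for it. Compound 2 `C/C(=N\Nc1nc(SCc2ccccc2)nc2c1nnn2Cc1ccccc1)c1ccccc1O` gives 1770 nM in this assay, and compound 3 `C#CCSc1nc(N/N=C/c2c(O)ccc3ccccc23)c2nnn(Cc3ccccc3)c2n1` gives 6520 nM. For the measured compounds named here, no single-change step links these three, so their values are simply read side by side. Compound 4 `CCCSc1nc(N/N=C/c2c[nH]c3ccccc23)c2nnn(Cc3ccccc3)c2n1` differs from compound 1 by 1H-indol-3-yl in place of 4-methylphenyl on a carbon with a double bond to nitrogen. With compound 1 known only as a limit, any step can only be guessed; a move toward stronger inhibition, beyond the scatter, seems plausible but far from certain. Compound 4 is expected near 20000 nM, within 5000 nM to 64000 nM. The expected step is an at least 3.2-fold lower number from compound 1 to compound 4 (0.50 log units; beyond the scatter).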

Compound 4, half-maximal inhibitory concentration: 8690 nM
Estimate against measurement, compound 4: 2.3-fold (0.36 log units) above; the measured number falls inside the stated range.
By their numbers in this assay, from the lowest: compound 2; then compounds 3 and 4 (each within the scatter of the next). At a limit, above all of these: compound 1.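

In this assay, 1H-indol-3-yl in place of 4-methylphenyl on a carbon with a double bond to nitrogen gives an at least 7.3-fold lower number from compound 1 to compound 4 (0.86 log units; beyond the scatter). This is the first single-change step among these compounds, and it shows that the group at this position can by itself move the number beyond the scatter. The value of compound 1 is a limit, not a number, so the full size of the step stays unknown: the limit of > 64000 nM in this assay, at which 1 of the 4 values shown sits.

Still open, on these data alone, is whether a 1-methyl-1H-indol-3-yl or a pyridyl group at this position would give a similar number. Also open, as far as these compounds go, is whether the same change would have a similar effect with a longer chain on the sulfur.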